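Swapping neopentyl for tert-butoxy on compound 3

The source may hold more compounds than are shown below. What is called first, only, known or untested is meant among the compounds shown, and "the series" means these compounds.

Compound 1: `Cc1cc(C(=O)Nc2cccc(F)c2)nn1Cc1cc(Cl)ccc1OCc1ccccc1`, 2.8
Compound 2: `Cc1cc(C(=O)NCc2ccncc2)nn1Cc1cc(Cl)ccc1OCc1ccccc1`, > 3.7
Compound 3: `Cc1cc(NC(=O)CC(C)(C)C)nn1Cc1cc(Cl)ccc1OCc1ccccc1`, > 3.7

In a physicochemical assay for lipophilicity, at pH 7.4 (on this read-out higher numbers stand for higher lipophilicity and lower numbers for lower lipophilicity), compound 1 gives a true number, 2.8. Compound 2 gives > 3.7, which is a limit of the assay and not a number. Compound 3 gives > 3.7, also a limit and not a number, so it stands at the limit of > 3.7 in this assay, at which 2 of the 3 values shown sit.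

Compound 4, `Cc1cc(NC(=O)OC(C)(C)C)nn1Cc1cc(Cl)ccc1OCc1ccccc1`, differs from compound 3 by one exchange: tert-butoxy in place of neopentyl on a carbonyl carbon. In short, tert-butoxy sits in place of neopentyl on a carbonyl carbon.

Two measured steps change the larger group that holds this carbonyl. One is a number at least 0.90 log units higher from compound 1 to compound 3 (beyond the scatter). The other is a step that the two limits leave unreadable from compound 2 to compound 3. The first replaces a whole group and the second cannot be sized, so neither isolates this smaller exchange. No step beyond the scatter is therefore expected in this assay, in either direction. The estimated step is a step that the limit leaves unreadable from compound 3 to compound 4. For compound 4 the expected value is 3.9, with an estimated range from 3.4 to 4.4.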

Compound 4, distribution coefficient: > 3.7
Compound 4 gave a limit, no number; the forecaster's own chance of this, stated with the estimate: 65%; the middle value is on the limit's open side.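

In this assay compound 4 gives > 3.7, a limit and not a number, and it joins the other compounds at that ceiling: the limit of > 3.7 in this assay, at which 3 of the 4 values shown sit.

Within the data shown here, the only readable comparison is a number at least 0.90 log units higher from compound 1 to compound 4 (beyond the scatter), so the (tert-butoxycarbonyl)amino group, like the (neopentylcarbonyl)amino group before it, lands clearly higher than the (3-fluorophenyl)carbamoyl group of compound 1. The steps to compound 4 from compound 2 and from compound 3 cannot be read, so tert-butoxy in place of neopentyl on a carbonyl carbon has no measurable size here, in either direction.

From the compounds shown here alone, how far compound 3 and compound 4 actually lie from each other stays open, as neither has a true number. Also open, going by these compounds, is whether a methyl group or an amine on this carbonyl carbon would give a true number in this assay.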